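Dichloro for Bromo on the Benzyl Arm: Expected Tolerance

The compounds below may be only part of what the source reports. "The series", "measured", "known", "first", "only" and "open" are said of these compounds alone.

Compound 1, `CCc1c(Cc2cccc(Br)c2)nc(SCc2ccc(OC)cc2)[nH]c1=O`: 201000 nM
Compound 2, `CCc1c(Cc2ccc(Br)cc2)nc(SCc2ccc(OC)cc2)[nH]c1=O`: > 281000 nM

In an ADME assay on MT4 cells (Homo sapiens) for cytotoxicity, read by MTT assay (a higher number here means that more compound is tolerated, a lower number that less compound is tolerated), compound 1 gives 201000 nM. For compound 2 this assay reports only a limit, > 281000 nM. The step of an at least 1.3-fold higher number from compound 1 to compound 2 (0.14 log units; that floor lies within the scatter) thus rests on that limit, (the limit of > 281000 nM in this assay, at which 1 of the 2 values shown sits). Compound 3, `CCc1c(Cc2c(Cl)cccc2Cl)nc(SCc2ccc(OC)cc2)[nH]c1=O`, differs from compound 2 by 2,6-dichlorophenyl in place of 4-bromophenyl on a saturated chain carbon bound to an aromatic carbon. Going by the values given here, no measured step touches this change directly, and the single step measured at the same place stayed within the scatter. Compound 3 is therefore expected to remain near compound 2, with an estimated step of an at least 1.1-fold lower number from compound 2 to compound 3 (0.05 log units; that floor lies within the scatter) not beyond the scatter. The estimate for compound 3 is 250000 nM, ranging from 100000 nM to 450000 nM.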

Compound 3, half-maximal cytotoxic concentration: > 287000 nM
Compound 3: no number, only a limit (the forecaster's own chance of this, stated with the estimate: 55%); middle value at least 1.1-fold (0.05 log units) away from the limit.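

With 2,6-dichlorophenyl on a saturated chain carbon bound to an aromatic carbon, compound 3 is also reported in this assay only as a limit: the limit of > 287000 nM in this assay, at which 1 of the 3 values shown sits.

Replacing the 3-bromophenyl of compound 1 with 2,6-dichlorophenyl gives an at least 1.4-fold higher number from compound 1 to compound 3 (0.15 log units; that floor lies within the scatter). The step from the 4-bromophenyl of compound 2 to this group cannot be read, as both values are limits.

Going by these compounds, how far the true values of compound 2 and compound 3 lie past their limits remains open. So does whether an amine or a carboxylic acid on this ring would lower the tolerated concentration.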